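The source may hold more compounds than are shown below. What is called first, only, known or untested is meant among the compounds shown, and "the series" means these compounds.

Measured so far:
- compound 1 `Cn1cc(-c2cnc3nc(O)n(Cc4ccc5ncccc5c4)c3n2)cn1`: > 10000 nM
- compound 2 `CCC(c1ccc2ncccc2c1F)n1cnc2ncc(-c3ccc(C(=O)OC)c(F)c3)nc21`: "not determined" (no result reported)
- compound 3 `CC(NC/N=C/c1ccnn1C)c1ccc2ncccc2c1`: 3290 nM

All three entries come from a functional assay on NCI-H1993 cells (Homo sapiens) for inhibition, read by CCK-8 assay, with a stated time of 72 h; a higher number here means a weaker inhibitor, a lower number a stronger inhibitor. For compound 1 the entry > 10000 nM is a limit of the assay and not a number. Compound 2 has no result. Among the measured compounds shown here, compound 3 at 3290 nM therefore holds the only actual number, with nothing to rank it against.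

Next is compound 4 `CC(NC/N=C/c1ccncc1)c1ccc2ncccc2c1`, with pyridin-4-yl in place of 1-methyl-1H-pyrazol-5-yl on a carbon with a double bond to nitrogen. For the measured compounds named here, no measured pair tests this kind of change, so no step beyond the scatter is expected in this assay, and the uncertainty stays wide. The expected change is a 1.1-fold lower number from compound 3 to compound 4 (0.04 log units; within the scatter). Compound 4 is estimated at 3000 nM, with an expected range of 800 nM to 10000 nM.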

Compound 4, half-maximal inhibitory concentration: 614 nM
Estimate against measurement, compound 4: 4.9-fold (0.69 log units) above; the measured number lies below the stated range.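

In this assay, among the compounds shown here, the ring on a carbon with a double bond to nitrogen clearly affects the read-out: the change to pyridin-4-yl gives a 5.4-fold lower number from compound 3 to compound 4 (0.73 log units; beyond the scatter) and is the only step here beyond the scatter, though it rests on a single pair. Nothing measured here accounts for this step.

Open, from the compounds shown here alone, is whether a plain phenyl ring or pyridin-3-yl on this carbon would keep the number of compound 4. Also open, going by these compounds, is whether an amine on the pyridin-4-yl ring would shift it further.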